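Fluoro Replacing Acetyl on the Shared Core: an Expectation

The source may hold more compounds than are shown below. What is called first, only, known or untested is meant among the compounds shown, and "the series" means these compounds.

Measured compounds:
compound 1, `CC(C)c1cccc(NC(=O)N[C@@H](C)c2ccccc2)c1`: 86%
compound 2, `C[C@H](NC(=O)Nc1cccc(C(F)(F)F)c1)c1ccccc1`: 92%
compound 3, `CC(=O)c1cccc(NC(=O)N[C@@H](C)c2ccccc2)c1`: 94%

In an ADME assay on the whole organism with Oryza sativa as the target, tested at 10 uM (on this read-out higher numbers stand for a weaker effect at the one concentration tested and lower numbers for a stronger effect), compound 3 gives 94%, the highest of the three numbers as they stand, though the nearest step to it is a number 2 percentage points higher from compound 2 to compound 3 (within the scatter) and the furthest a number 8 percentage points higher from compound 1 to compound 3 (within the scatter), so all three lie within the scatter of one another. Compound 4, `C[C@H](NC(=O)Nc1cccc(F)c1)c1ccccc1`, is not yet measured; it arises from compound 3 by fluoro in place of acetyl on an aromatic carbon. Among the compounds with values here, no measured step makes this exact exchange, but all three measured steps vary the group on the same aromatic carbon: a number 6 percentage points higher from compound 1 to compound 2 (within the scatter), a number 8 percentage points higher from compound 1 to compound 3 (within the scatter) and a number 2 percentage points higher from compound 2 to compound 3 (within the scatter), each within the scatter. A step no larger than the scatter in this assay is therefore expected, in no particular direction. Compound 4 is estimated at 90%, between 78% and 99%, which means an expected step of a number 4 percentage points lower from compound 3 to compound 4 (within the scatter).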

Compound 4, a percentage reported as activity, at one concentration (the size of the read-out at that concentration, not a potency): 88%
For compound 4 the middle estimate is 2 percentage points above the measured one; measured number inside the range.
By their numbers in this assay, from the lowest: compounds 1, 4, 2 and 3 (each within the scatter of the next).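

With a fluoro on this aromatic carbon, the number in this assay stays within the scatter of all three earlier groups (acetyl: a number 6 percentage points lower from compound 3 to compound 4 (within the scatter); trifluoromethyl: a number 4 percentage points lower from compound 2 to compound 4 (within the scatter); isopropyl: a number 2 percentage points higher from compound 1 to compound 4 (within the scatter)). Even with a single heavy atom in place of the acetyl and its carbonyl, this position shows no step beyond the scatter. Nothing measured here offers a reason for this.

As far as these compounds go, whether an amine, a carboxylic acid or a longer chain at this position would give a step beyond the scatter remains open. So does whether changes elsewhere on the shared core would do so.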